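A Hydroxyl Exchanged for a Methoxy Group, Twice

The compounds below may be only part of what the source reports. "The series", "measured", "known", "first", "only" and "open" are said of these compounds alone.

Compound 1 `O=C(/C=C(/C=C/c1ccc(O)cc1)NCCCO)/C=C/c1ccc(O)cc1` and compound 2 `COc1cc(/C=C/C(=O)/C=C(/C=C/c2ccc(O)c(OC)c2)NCCCO)ccc1O` are built on closely related cores; the difference between the two cores is not broken down here. In an ADME assay on CHO-K1 cells (Cricetulus griseus) for activation, read by fluorescence, tested at 1 uM (a higher number here means a weaker effect of the compound at the concentration tested, a lower number a stronger effect), compound 1 gives 86.4% and compound 2 gives 90.4%. Compound 3 `COCCNC(=C\C(=O)/C=C/c1ccc(O)cc1)/C=C/c1ccc(O)cc1` differs from compound 1 by methoxy in place of hydroxymethyl on a saturated chain carbon, two bonds along the chain from an amine nitrogen. In this assay compound 3 gives 82.5%, which is a number 3.9 percentage points lower from compound 1 to compound 3 (within the scatter). For the measured compounds named here, compound 4 `COCCNC(=C\C(=O)/C=C/c1ccc(O)c(OC)c1)/C=C/c1ccc(O)c(OC)c1` has no measurement yet; it differs from compound 2 by methoxy in place of hydroxymethyl on a saturated chain carbon, two bonds along the chain from an amine nitrogen, the same change made at the same place. Because the measured step of a number 3.9 percentage points lower from compound 1 to compound 3 (within the scatter) lay within the scatter, the step from compound 2 to compound 4 is expected to be about as small, a number 3.9 percentage points lower from compound 2 to compound 4 (within the scatter). For compound 4 the expected value in this assay is therefore 86.5%, estimated to fall between 76% and 96%.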

Compound 4, a percentage reported as activity, at one concentration (the size of the read-out at that concentration, not a potency): 94%
The estimate for compound 4 lay 7.5 percentage points below the measured number; the measured number falls inside the stated range.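

In this assay, replacing the (3-hydroxypropyl)amino group with the (2-methoxyethyl)amino group gives a number 3.6 percentage points higher from compound 2 to compound 4 (within the scatter). The two cores show no detectable difference in how they respond to this change: the same change on two cores in this assay, a number 3.9 percentage points lower (within the scatter) from compound 1 to compound 3 and a number 3.6 percentage points higher (within the scatter) from compound 2 to compound 4, 7.5 percentage points apart, within the scatter of two such steps. For the compounds shown here, this shows only that the exchange left the read-out within the scatter on both cores; with just these two pairs, it does not show that the steps are truly identical, that the opposite signs mean anything, or that another core would behave the same way.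

The compounds shown leave open what a longer chain, an amine or a carboxylic acid would do in place of the 3-hydroxypropyl group. They also leave open whether the exchange stays this small at other concentrations.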